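This account rests on a few compounds, and the source may have more. Where it says the series, first, only, none or still open, it means among the compounds named here.

In a functional assay on HL-60 cells (Homo sapiens) for inhibition, read by CCK-8 assay, with a stated time of 48 h, tested at 20 uM (on this read-out higher numbers stand for more inhibition of growth at the one concentration tested and lower numbers for less inhibition of growth), compound 1 (`COc1ccc(Cc2nnc(NC(=O)/C(C#N)=C/c3ccccc3OS(=O)(=O)c3ccc(C)cc3)s2)cc1`) gives 25%, level with compound 3 (`COc1ccc(Cc2nnc(NC(=O)/C(C#N)=C/c3ccccc3OS(=O)(=O)c3ccccc3[N+](=O)[O-])s2)cc1`) at 25%. Together they hold the lowest number of the three, while compound 2 (`COc1ccc(Cc2nnc(NC(=O)/C(C#N)=C/c3ccccc3OS(=O)(=O)c3ccc(OC)cc3)s2)cc1`) reaches 100%. Compound 4 (`Cc1ccc(S(=O)(=O)Oc2ccccc2/C=C(\C#N)C(=O)Nc2nnc(Cc3ccc(F)cc3)s2)cc1`) has fluoro in place of methoxy on an aromatic carbon, para to a large group: fluoro in place of methoxy on an aromatic carbon. Among the compounds with values here, no measured step touches that place. The nearest evidence concerns the group on the sulfonyl sulfur: a number 75 percentage points higher from compound 1 to compound 2 (beyond the scatter) is large, no change at the digits printed from compound 1 to compound 3 (within the scatter) stays within the scatter, and a number 75 percentage points lower from compound 2 to compound 3 (beyond the scatter) is large again. The read-out can therefore jump, but nothing shows the direction for this change. A modest step is expected: a number 10 percentage points higher from compound 1 to compound 4 (within the scatter). Compound 4 is estimated at 35%, with an expected range of 15% to 80%.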

Compound 4, percent growth inhibition at one concentration: "not active" (no number reported)
Compound 4 has no reported number here; the estimate stays without a comparison.
By their numbers in this assay, from the lowest: compounds 1 and 3 (each within the scatter of the next); then compound 2.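

Within the data shown here, compound 4 is reported only as "not active" in this assay, without a number, so no step linking it to compound 1, compound 2 or compound 3 can be read. From the compounds shown here alone, what stays open is how far 4-fluorobenzyl in place of 4-methoxybenzyl shifts growth inhibition. No measurement shown explains this result.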